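Aryl swap on the sulfonamide nitrogen of the shared core

The source may report more compounds than this note shows. Statements on the series, on what has been measured and on what is new or still open speak of the compounds shown alone.

The series shares the core of compound 1 `Cc1oncc1NS(=O)(=O)c1ccc(F)c2ncc(I)cc12` and varies only the group attached to the sulfonyl sulfur. In an assay for inhibition of methylcytosine dioxygenase TET2 (Homo sapiens), read by mass spectrometry, with stated times of 30 min and 1 h (a lower number here means a stronger inhibitor, a higher number a weaker inhibitor), compound 1 gives 2100 nM, the lowest of the two numbers in hand. Compound 2 `O=S(=O)(O)c1ccc(F)c2ncc(I)cc12` gives 2300 nM in this assay, and the step of a 1.1-fold higher number from compound 1 to compound 2 (0.04 log units; within the scatter) lies within the scatter. Compound 3 `CCOS(=O)(=O)c1ccc(F)c2ncc(I)cc12` reaches only a limit of the assay, > 200000 nM. The steps of an at least 95-fold higher number from compound 1 to compound 3 (1.97 log units; beyond the scatter) and an at least 86-fold higher number from compound 2 to compound 3 (1.93 log units; beyond the scatter) are large, resting on that limit (the limit of > 200000 nM in this assay, at which 1 of the 3 values shown sits).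

Compound 4 `COc1cccc(NS(=O)(=O)c2ccc(F)c3ncc(I)cc23)c1` keeps the sulfonamide and changes only the group on its nitrogen: 3-methoxyphenyl in place of 5-methyl-1,2-oxazol-4-yl on a sulfonamide nitrogen. The three measured steps are the only ones touching the sulfonyl substituent. Between compound 1 and compound 2 the whole oxazolyl amine gives way to a hydroxyl without a step beyond the scatter, whereas the ethyl ester of compound 3 loses most of the activity. An aryl for aryl exchange on the sulfonamide nitrogen is therefore expected to resemble the first case rather than the second, giving no step beyond the scatter, a 1.1-fold lower number from compound 1 to compound 4 (0.02 log units; within the scatter). Compound 4 is estimated at 2000 nM in this assay, with a range from 700 nM to 6000 nM.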

Compound 4, half-maximal inhibitory concentration: > 200000 nM
Compound 4: only a limit was reported; the forecaster's own chance of this, stated with the estimate: 5%; at least 100-fold (2.00 log units) between middle value and limit.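

For the compounds shown here, on the sulfonamide nitrogen, the identity of the group matters far more than the earlier compounds could show: with the sulfonamide kept, 3-methoxyphenyl in place of 5-methyl-1,2-oxazol-4-yl gives an at least 95-fold higher number from compound 1 to compound 4 (1.97 log units; beyond the scatter) in this assay. Keeping the sulfonamide is therefore not enough to keep the activity, and compound 2, which has no sulfonamide yet stays within the scatter of compound 1, goes against any reading that ties activity to that linkage. In this assay compound 4 gives > 200000 nM, which is a limit and not a number, so the step gives only a lower bound on the loss, and compound 4 now rests at the same limit as compound 3: the limit of > 200000 nM in this assay, at which 2 of the 4 values shown sit.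

The change swaps the ring and adds the methoxy group in one step, so the compounds shown do not separate the two; a plain phenyl on the sulfonamide nitrogen would be the single-change comparison. Also open, on these data alone, is whether a carboxylic acid or an amine on that aryl ring, or a 5-membered ring other than the 1,2-oxazole, would return to the level of compound 1.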